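A few compounds are considered here, and "the series" means these few. Any claim that something is new, unique, unknown or untested is made for them only; others in the source may bear on it.

Measured in a physicochemical assay for solubility, read by nephelometry, measured as kinetic solubility, at pH 2, tested at 10 mg/mL; a lower number here means a less soluble compound, a higher number a more soluble compound:
- Compound 1 `Cc1ccccc1C(=O)Nc1cccc(F)n1`: > 100 ug/mL (a limit, not a number)
- Compound 2 `COc1ccc(NC(=O)c2ccccc2C)nc1`: > 100 ug/mL (a limit, not a number)

Compound 2 therefore has no exact position in the series, only a limit. The record so far reads: the limit of > 100 ug/mL in this assay, at which 2 of the 2 values shown sit. Among the measured compounds shown here, neither compound gives an exact reading, and no measured pair differs in one place, so the data show no step size.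

Compound 3 `Cc1ccccc1C(=O)Nc1ccc(C#N)cn1` is the next compound to be read. It has cyano in place of methoxy on an aromatic carbon, on a six-membered aromatic ring with 1 nitrogen, two atoms from the ring nitrogen and para to a large group: cyano in place of methoxy on an aromatic carbon.

The expectation rests on compound 2, which gives > 100 ug/mL, a limit. No step beyond the scatter is expected in this assay, with only a slight lean downward, and the assay may again report only a limit. The estimated step is an at least 1.1-fold lower number from compound 2 to compound 3 (0.04 log units; that floor lies within the scatter). The estimated value for compound 3 is 90 ug/mL, with an expected range of 40 ug/mL to 130 ug/mL.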

Compound 3, solubility: 6.3 ug/mL
Compound 3: middle estimate off by 14-fold (1.15 log units), on the high side; measured number below the stated range.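

In this assay, cyano in place of methoxy on an aromatic carbon, two atoms from the ring nitrogen and para to a large group, gives an at least 15-fold lower number from compound 2 to compound 3 (1.20 log units; beyond the scatter). This is the first evidence that the reading responds to the group at this position, and compound 3 provides the only exact reading among the compounds shown. As the two groups are equal in heavy atoms and hydrogen-bond acceptors as counted, those counts alone do not set the reading for this pair; the step is only a floor, since the reading for compound 2 is a limit and not a number: the limit of > 100 ug/mL in this assay, at which 2 of the 3 values shown sit.

From the compounds shown here alone, it remains open whether this large step is particular to cyano or would also appear with another group at the same position, such as an amine or a chlorine atom. Also open, going by these compounds, is how far the true reading of compound 2 lies beyond its limit, and so how large the step between methoxy and cyano really is.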